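Methoxy to hydroxy: expected step for compound 3

The source may report more compounds than this note shows. Statements on the series, on what has been measured and on what is new or still open speak of the compounds shown alone.

Going by the values given here, in a functional assay on HepG2 cells (Homo sapiens) for antiproliferative activity, read by sulforhodamine B assay, with a stated time of 48 h (a higher number here means a weaker inhibitor, a lower number a stronger inhibitor), compound 1 `COc1ccc(C(=O)/C=C/c2ccccc2-c2ccc(F)cc2)cc1OC` gives 6600 nM, the highest of the two numbers so far, while compound 2 `COc1cc(C(=O)/C=C/c2ccccc2-c2ccc(F)cc2)ccc1O` gives 3100 nM. Compound 3 `COc1ccc(C(=O)/C=C/c2ccccc2-c2ccc(F)cc2)cc1O`, not yet measured, differs from compound 1 by hydrogen in place of methyl on an oxygen on an aromatic ring, a methoxy to hydroxy exchange. Among the compounds with values here, one measured step bears on it: a 2.1-fold lower number from compound 1 to compound 2 (0.33 log units; beyond the scatter), a modest step from the same kind of exchange at the other methoxy. Within the data shown here, with only this step as support, a similarly modest move to a lower number is expected in this assay. The estimated step is a 1.9-fold lower number from compound 1 to compound 3 (0.28 log units; within the scatter). Compound 3 is expected at 3500 nM, with an estimated range of 1500 nM to 8000 nM.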

Compound 3, half-maximal inhibitory concentration: 190 nM
Beside the measured number, compound 3's estimate is 18-fold (1.27 log units) above it, outside the stated range (below it).
By their numbers in this assay, from the lowest: compound 3; then compound 2; then compound 1.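

In this assay the methoxy to hydroxy exchange is not equivalent at the two methoxy groups of compound 1: this position gives a 35-fold lower number from compound 1 to compound 3 (1.54 log units; beyond the scatter) at this methoxy, against a 2.1-fold lower number from compound 1 to compound 2 (0.33 log units; beyond the scatter) at the other methoxy. Within these three compounds, the size of the step depends on which oxygen carries the hydrogen. Nothing measured here accounts for that difference.

Still open, as far as these compounds go, is whether the low number requires the hydroxy itself or would persist with an amine or a longer chain such as ethoxy at this position. From the compounds shown here alone, whether the large step holds on another core also remains open.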